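The compounds below may be only part of what the source reports. "The series", "measured", "known", "first", "only" and "open" are said of these compounds alone.

Two compounds of the series carry numbers in an assay for inhibition of Amine oxidase [flavin-containing] B (Homo sapiens), read by fluorescence, using microsomes, with a stated time of 30 min; on this read-out lower numbers stand for stronger inhibition and higher numbers for weaker inhibition. Compound 1 `CN(C)Cc1ccc(COc2ccc3c(CO)cc(=O)oc3c2)cc1` gives 78 nM, and compound 2 `Cc1c(C)c2ccc(OCC3CCN(Cc4ccc(CCO)cc4)CC3)cc2oc1=O` gives 120 nM; the gap between the two lies within the scatter, so neither stands apart from the other on this read-out. Compound 3 `Cc1c(C)c2ccc(OCC3CCN(CCCO[N+](=O)[O-])CC3)cc2oc1=O` has not been measured; it differs from compound 2 by 2-(nitrooxy)ethyl in place of 4-(2-hydroxyethyl)phenyl on a saturated chain carbon bound to an amine nitrogen in a ring. Going by the values given here, no step between measured compounds covers a change of this kind, so nothing measured fixes its direction. With the aromatic ring of the leaving group gone, a weaker number is expected, a step of a 2.9-fold higher number from compound 2 to compound 3 (0.46 log units; beyond the scatter) beyond the scatter. Compound 3 is estimated at 350 nM, within 90 nM to 1500 nM.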

Compound 3, half-maximal inhibitory concentration: 250 nM
Compound 3: middle estimate off by 1.4-fold (0.15 log units), on the high side, within the range that was stated.
By their numbers in this assay, from the lowest: compounds 1 and 2 (each within the scatter of the next); then compound 3.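

In this assay the swap of 4-(2-hydroxyethyl)phenyl for 2-(nitrooxy)ethyl on a saturated chain carbon bound to an amine nitrogen in a ring is a 2.1-fold higher number from compound 2 to compound 3 (0.32 log units; beyond the scatter) and remains modest. Compound 3 at 250 nM shows that inhibition at this position survives without that aromatic ring. No measurement here gives a reason for the step.

As far as these compounds go, the ring and the nitrooxy end change together, so their separate shares in the step stay open. A 3-hydroxypropyl group in place of 3-(nitrooxy)propyl would separate them.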